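The compounds below may be only part of what the source reports. "The series", "measured", "known", "first", "only" and "open" are said of these compounds alone.

Working notes on the series.

In a functional assay on Caco-2 cells (Homo sapiens) for activation, read by fluorescence, tested at 1 uM (a higher number here means a weaker effect of the compound at the concentration tested, a lower number a stronger effect), compound 1 `O=C(/C=C(/C=C/c1ccc(O)cc1)NCCCO)/C=C/c1ccc(O)cc1` gives 94.1%. In the same assay compound 2 `COCCNC(=C\C(=O)/C=C/c1ccc(O)cc1)/C=C/c1ccc(O)cc1` gives 94.9%. Compound 3 `O=C(/C=C(/C=C/c1ccc(O)cc1)NCCO)/C=C/c1ccc(O)cc1` gives 98.1%, the highest of the three numbers, though all three sit within the scatter of one another: the gap to its nearest neighbour is a number 3.2 percentage points higher from compound 2 to compound 3 (within the scatter), the gap to the furthest is a number 4 percentage points higher from compound 1 to compound 3 (within the scatter). Going by the values given here, nothing among the measured compounds therefore separates any one from the others.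

The next compound, compound 4 `COCCCNC(=C\C(=O)/C=C/c1ccc(O)cc1)/C=C/c1ccc(O)cc1`, differs from compound 3 as follows: methoxymethyl in place of hydroxy on a saturated chain carbon, two bonds along the chain from an amine nitrogen. Among the compounds with values here, the steps that bear on this change are the removal of the methyl from the oxygen, a number 3.2 percentage points higher from compound 2 to compound 3 (within the scatter), the shortening of the chain, a number 4 percentage points higher from compound 1 to compound 3 (within the scatter), and the exchange of the hydroxyl for a methoxy, a number 0.8 percentage points higher from compound 1 to compound 2 (within the scatter); every one of them stayed within the scatter. On that basis the step of a number 3.1 percentage points lower from compound 3 to compound 4 (within the scatter) is expected to be without direction beyond the scatter. For compound 4 the estimated value in this assay is 95%, with a range from 87% to 101%.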

Compound 4, a percentage reported as activity, at one concentration (the size of the read-out at that concentration, not a potency): 97%
Compound 4: middle estimate off by 2 percentage points, on the low side; the range from low to high includes it.
By their numbers in this assay, from the lowest: compounds 1, 2, 4 and 3 (each within the scatter of the next).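

In this assay, 3-methoxypropyl in place of 2-hydroxyethyl on the amine nitrogen gives a number 1.1 percentage points lower from compound 3 to compound 4 (within the scatter), and methoxymethyl in place of methoxy at the same place gives a number 2.1 percentage points higher from compound 2 to compound 4 (within the scatter), so adding to the chain and removing the hydrogen-bond donor together still leave no step beyond the scatter. Placing a methyl on the chain oxygen gives a number 2.9 percentage points higher from compound 1 to compound 4 (within the scatter), which means this change can now be read on two cores. The two readings show no shared direction that stands out from the scatter: the same change on two cores in this assay, a number 3.2 percentage points higher (within the scatter) from compound 2 to compound 3 and a number 2.9 percentage points lower (within the scatter) from compound 4 to compound 1, 6.1 percentage points apart, within the scatter of two such steps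

With all four compounds within the scatter of one another at one concentration, this position has yet to show any group that moves the read-out. From the compounds shown here alone, whether a basic amine, a carboxylic acid, a phenyl group or a much longer chain at this place would do so remains open.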